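Thiosemicarbazones: nitrophenyl to chlorophenyl swap on the hydrazone carbon

This account rests on a few compounds, and the source may have more. Where it says the series, first, only, none or still open, it means among the compounds named here.

The series shares the core of compound 1 `CC1=CC[C@@H]([C@@](C)(O)CCCC(C)(C)NC(=S)NN)CC1`. In a functional assay on HT-29 cells (Homo sapiens) for cytotoxicity, read by sulforhodamine B assay (on this read-out lower numbers stand for stronger inhibition of growth and higher numbers for weaker inhibition of growth), compound 1 gives 49400 nM. Compound 2 `CC1=CC[C@@H]([C@@](C)(O)CCCC(C)(C)NC(=S)N/N=C\c2ccc([N+](=O)[O-])cc2)CC1` gives 12300 nM in this assay, the lower of the two numbers, with compound 1 standing above it by more than the scatter. Compound 3 `CC1=CC[C@@H]([C@@](C)(O)CCCC(C)(C)NC(=S)N/N=C\c2ccccc2Cl)CC1` carries 2-chlorophenyl in place of 4-nitrophenyl on a carbon with a double bond to nitrogen. Within the data shown here, no measured pair covers this change, so nothing sets its size. The expected step of a 1.3-fold higher number from compound 2 to compound 3 (0.11 log units; within the scatter) is small, likely within the scatter, leaning toward a slightly higher number. Compound 3 is estimated at 16000 nM, with a range from 5000 nM to 50000 nM.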

Compound 3, concentration for 50% growth inhibition: 23700 nM
Compound 3: middle estimate off by 1.5-fold (0.17 log units), on the low side; the measured number falls inside the stated range.
By their numbers in this assay, from the lowest: compounds 2 and 3 (each within the scatter of the next); then compound 1.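

The swap of 4-nitrophenyl for 2-chlorophenyl on a carbon with a double bond to nitrogen gives a 1.9-fold higher number from compound 2 to compound 3 (0.28 log units; within the scatter) in this assay and so does not separate these two groups at this position. The modest step of a 2.1-fold lower number from compound 1 to compound 3 (0.32 log units; beyond the scatter) shows that a number lower than that of compound 1 is not confined to the 4-nitrophenyl group. Nothing available explains either step.

Going by these compounds, whether an unsubstituted phenyl, a 4-chlorophenyl or a cyclohexyl group here would give similar numbers remains open.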